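Sulfonylurea series on rat aorta: aryl chloro to hydrogen

The source may report more compounds than this note shows. Statements on the series, on what has been measured and on what is new or still open speak of the compounds shown alone.

Measured compounds:
compound 1, `CCOc1ccc(F)cc1C(C)NC(=O)NS(=O)(=O)c1ccc(Cl)cc1`: > 300000 nM
compound 2, `CCOc1ccc(Cl)cc1C(C)NC(=O)N(C)S(=O)(=O)c1ccccc1`: 10500 nM
compound 3, `CCOc1ccc(Cl)cc1C(C)NC(=O)N(C)S(=O)(=O)c1ccc(Cl)cc1`: 14600 nM

Three compounds of the series have been run in a functional assay on thoracic aorta (Rattus norvegicus, strain Wistar), with a stated time of 15 min; a higher number here means that more compound is needed for the effect, a lower number that less compound is needed. Compound 2 gives 10500 nM in this assay. Compound 3 gives 14600 nM in this assay. The two differ only by hydrogen in place of chloro on an aromatic carbon; the measured step is a 1.4-fold lower number from compound 3 to compound 2 (0.14 log units; within the scatter).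

Compound 1 gives > 300000 nM in this assay, which is a limit of the assay and not a number; this is the limit of > 300000 nM in this assay, at which 1 of the 3 values shown sits. The difference between the core of compound 1 and the core of compound 3 is not broken down here.

Compound 4 `CCOc1ccc(F)cc1C(C)NC(=O)NS(=O)(=O)c1ccccc1` has not yet been measured in this assay. It differs from compound 1 by hydrogen in place of chloro on an aromatic carbon, the same change that separates compound 3 and compound 2, at the same place on the ring. Resting on a 1.4-fold lower number from compound 3 to compound 2 (0.14 log units; within the scatter), the expected step is a step that the limit leaves unreadable from compound 1 to compound 4. Compound 1 returns only a limit in this assay, so for compound 4 the expectation is that a limit, or a value near it, is returned again. The estimate for compound 4 in this assay is 400000 nM, with a range from 100000 nM to 2000000 nM, and the expectation rests on compound 1 and on the measured step of compound 3 to compound 2 alone.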

Compound 4, half-maximal effective concentration: > 300000 nM
Compound 4: only a limit was reported (the forecaster's own chance of this, stated with the estimate: 70%); the middle value is on the limit's open side.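

In this assay compound 4 returns a limit and not a number, as compound 1 does, so no step can be read for 4-chlorophenyl to phenyl on this pair: the limit of > 300000 nM in this assay, at which 2 of the 4 values shown sit.

The compounds shown leave open whether hydrogen in place of chloro on an aromatic carbon changes the read-out at all on the core of compound 1, and how far that core stands from the core of compound 3.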